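A Dichlorophenyl Thioether Joins the Series

This account rests on a few compounds, and the source may have more. Where it says the series, first, only, none or still open, it means among the compounds named here.

Compound 1 `CCOC(=O)[C@H](CCC(=O)O)NC(=O)c1ccc(Sc2nc3cc(N)cc(N)c3nc2-c2ccccc2)cc1`: 17400 nM
Compound 2 `Nc1cc(N)c2nc(-c3ccccc3)c(Sc3ccc(F)cc3)nc2c1`: 16600 nM
Compound 3 `COc1cc(CNc2nc3cc(N)cc(N)c3nc2-c2ccccc2)cc(OC)c1OC`: 3470 nM

In a functional assay on UACC-257 cells (Homo sapiens) for inhibition, read by sulforhodamine B assay, with a stated time of 48 h (on this read-out higher numbers stand for weaker inhibition of growth and lower numbers for stronger inhibition of growth), compound 2 gives 16600 nM, the second highest of the three numbers. Compound 1 at 17400 nM sits within the scatter of compound 2, so the two cannot be told apart. Compound 3 at 3470 nM lies beyond the scatter, with the lower number.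

Compound 4 `Nc1cc(N)c2nc(-c3ccccc3)c(Sc3ccc(Cl)c(Cl)c3)nc2c1` has not been measured. It differs from compound 2 by 3,4-dichlorophenyl in place of 4-fluorophenyl on a sulfur. Among the measured compounds shown here, no measured pair records this change, so its size is not known from the data. A small step in this assay toward a lower number, probably within the scatter, is expected: a 1.4-fold lower number from compound 2 to compound 4 (0.14 log units; within the scatter). Compound 4 is therefore estimated at 12000 nM, with a range from 4000 nM to 35000 nM.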

Compound 4, concentration for 50% growth inhibition: 17800 nM
For compound 4 the middle estimate is 1.5-fold (0.17 log units) below the measured one, within the range that was stated.
By their numbers in this assay, from the lowest: compound 3; then compounds 2, 1 and 4 (each within the scatter of the next).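

Among the compounds shown here, with 3,4-dichlorophenyl in place of 4-fluorophenyl on a sulfur, this assay records a 1.1-fold higher number from compound 2 to compound 4 (0.03 log units; within the scatter) and so gives the first direct reading of a change at this position. The two groups cannot be told apart here, so the added chlorine and the loss of fluorine together leave the number within the scatter. Nothing on hand offers a reason for this result.

From the compounds shown here alone, it remains open whether an amine on this phenyl ring would move the number beyond the scatter. The same question stands for a longer chain in place of the phenyl ring on the sulfur.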